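A few compounds are considered here, and "the series" means these few. Any claim that something is new, unique, unknown or untested is made for them only; others in the source may bear on it.

In an ADME assay on MCF-10A cells (Homo sapiens) for cytotoxicity, read by MTT assay, with a stated time of 48 h (on this read-out higher numbers stand for weaker inhibition and lower numbers for stronger inhibition), compound 2 `COc1ccc(-c2nnc(COc3ccc(-c4nnco4)cc3)o2)cc1` gives only a limit of the assay, > 100000 nM, and not a number. Compound 1 `COc1cc(C#N)ccc1OCc1nnc(-c2ccc(F)cc2)o1` likewise gives a limit there, > 100000 nM. Both values sit at the same boundary (the limit of > 100000 nM in this assay, at which 2 of the 2 values shown sit). Compound 3 `Clc1ccc(-c2nnc(COc3ccc(-c4nnco4)cc3)o2)cc1` differs from compound 2 by chloro in place of methoxy on an aromatic carbon. Going by the values given here, no step between measured compounds is known, and compound 2 offers only a limit, so no change beyond the scatter is expected from this exchange. Compound 3 is therefore expected to give about 100000 nM, somewhere between 40000 nM and 300000 nM. The step expected is a number no higher from compound 2 to compound 3 (the limit leaves the size open).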

Compound 3, half-maximal inhibitory concentration: > 100000 nM
Compound 3: only a limit was reported; the forecaster's own chance of this, stated with the estimate: 80%; the middle value sits exactly at the limit.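

Compound 2 and compound 3 both give only a limit in this assay, so no step can be read between them: the limit of > 100000 nM in this assay, at which 3 of the 3 values shown sit.

The compounds shown leave open whether methoxy and chloro differ at all in this assay, and what change would bring a value inside the measurable range.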